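Swapping Fluoro for Amino on the Aryl Ring

The source may report more compounds than this note shows. Statements on the series, on what has been measured and on what is new or still open speak of the compounds shown alone.

Compound 2 `Cc1nn(C)c2c1C(c1cccc(F)c1)=NCCN2` gives 2.5 mg/kg in a functional assay on the whole organism for positive allosteric modulation, with Rattus norvegicus as the target; on this read-out lower numbers stand for an effect already at smaller amounts and higher numbers for an effect only at larger amounts of compound; this is level with compound 3 `CCc1nn(C)c2c1C(c1cccc(F)c1)=NCCN2`, which gives 2.5 mg/kg, and together the two are the highest of three numbers, while compound 1 `Cc1nn(C)c2c1C(c1cccc(Br)c1)=NCCN2` gives 0.63 mg/kg. Compound 4 `Cc1nn(C)c2c1C(c1cccc(N)c1)=NCCN2` differs from compound 2 by amino in place of fluoro on an aromatic carbon. For the measured compounds named here, the one measured step at that same aromatic carbon, a 4.0-fold higher number from compound 1 to compound 2 (0.60 log units; beyond the scatter), shows that the number can move when this group changes; the other step, no change at the digits printed from compound 2 to compound 3 (within the scatter), sits elsewhere and did not move it. Neither step involves an amino group, so no step beyond the scatter is expected, though with wide uncertainty. Compound 4 is therefore estimated at 2.5 mg/kg, within 0.8 mg/kg to 8 mg/kg, an expected step of no change at the digits printed from compound 2 to compound 4 (within the scatter).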

Compound 4, minimum effective dose: 2.5 mg/kg
The estimate for compound 4 equals the measured number at the digits printed; low and high end bracket the measured number.
By their numbers in this assay, from the lowest: compound 1; then compounds 2, 3 and 4 (each within the scatter of the next).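

At this aromatic carbon, in this assay, the step is no change at the digits printed from compound 2 to compound 4 (within the scatter), so fluoro and amino cannot be told apart even though amino brings a hydrogen-bond donor that fluoro lacks. Among the three groups seen here, bromo alone stands apart, with a 4.0-fold higher number from compound 1 to compound 4 (0.60 log units; beyond the scatter) in the same direction as the step from bromo to fluoro. No evidence is available on why these groups compare this way.

Still open, on these data alone, is whether chloro, methoxy or trifluoromethyl at this carbon would match bromo or match fluoro and amino.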